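Methoxy to 4-fluorophenyl on the pyridine-bearing alkyne

The source may hold more compounds than are shown below. What is called first, only, known or untested is meant among the compounds shown, and "the series" means these compounds.

Three compounds of the series have numbers in a functional assay on CHO cells for agonist activity at metabotropic glutamate receptor 5 (Homo sapiens), read by inositol phosphate accumulation; on this read-out higher numbers stand for weaker inhibition and lower numbers for stronger inhibition. Compound 1 `Cc1nc(C#Cc2cccc(F)c2)cs1` gives 23 nM and compound 3 `C#Cc1cncc(C#Cc2csc(C)n2)c1` gives 19.2 nM; compound 2 `COc1ccc(C#Cc2csc(C)n2)cn1` gives 426 nM, the highest of the three, set well beyond the scatter from both compound 1 and compound 3. Compound 4 `Cc1nc(C#Cc2ccc(-c3ccc(F)cc3)nc2)cs1` differs from compound 2 by 4-fluorophenyl in place of methoxy on an aromatic carbon, on an aromatic carbon of a six-membered aromatic ring with 1 nitrogen. Among the compounds with values here, no measured pair shows this change. Since compound 1 gives 23 nM and compound 3 gives 19.2 nM without the methoxy, the expectation is a step toward a lower number, a 14-fold lower number from compound 2 to compound 4 (1.15 log units; beyond the scatter), beyond the scatter. Compound 4 is estimated at 30 nM in this assay, within 8 nM to 150 nM.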

Compound 4, half-maximal inhibitory concentration: 10.2 nM
Compound 4: middle estimate off by 2.9-fold (0.47 log units), on the high side; measured number inside the range.
By their numbers in this assay, from the lowest: compounds 4, 3 and 1 (each within the scatter of the next, the first and the last beyond it); then compound 2.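

In this assay, 4-fluorophenyl in place of methoxy on the aromatic carbon next to the ring nitrogen gives a 42-fold lower number from compound 2 to compound 4 (1.62 log units; beyond the scatter), a large step. Among the compounds shown, this position is thus not limited to methoxy: it also accepts an added aromatic ring, and the number falls rather than rises. Nothing measured bears on the reason for this step.

Going by these compounds, it remains open whether the step depends on the fluorine or on the ring alone. An unsubstituted phenyl, an amine or a carboxylic acid at this position would test how far it extends.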